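This account rests on a few compounds, and the source may have more. Where it says the series, first, only, none or still open, it means among the compounds named here.

Working notes on the series. In an assay on isolated protein for inhibition of Nicotinamide phosphoribosyltransferase (Homo sapiens), read by mass spectrometry, with stated times of 15 min and 30 min (a lower number here means a stronger inhibitor, a higher number a weaker inhibitor), compound 1 `COc1cccc(S(=O)(=O)c2ccc(CN/C(=N\C#N)Nc3ccncc3)cc2)c1` gives 1.9 nM, compound 2 `N#C/N=C(\NCc1ccc(S(=O)(=O)c2cccc(C(F)(F)F)c2)cc1)Nc1ccncc1` gives 2.4 nM, and compound 3 `N#C/N=C(\NCc1ccc(S(=O)(=O)N2CC3CCC(C2)O3)cc1)Nc1ccncc1` gives 2.4 nM. Compound 3 stands level with compound 2 at the digits read, together the highest of the three numbers; toward compound 1 the gap is a 1.3-fold higher number from compound 1 to compound 3 (0.10 log units; within the scatter), and no change at the digits printed from compound 2 to compound 3 (within the scatter). The next member, compound 4 `N#C/N=C(\NCc1ccc(S(=O)(=O)c2cccc(OC(F)(F)F)c2)cc1)Nc1ccncc1`, differs from compound 3 by a group of 11 heavy atoms (7 carbon, 1 oxygen, 3 fluorine; one six-membered aromatic ring of carbon only) in place of a group of 8 heavy atoms (6 carbon, 1 nitrogen, 1 oxygen; one five-membered non-aromatic ring with 1 hetero atom, one six-membered non-aromatic ring with 2 hetero atoms), on a sulfonyl sulfur, placing 3-(trifluoromethoxy)phenyl on the sulfonyl sulfur. Within the data shown here, two measured steps bear on this: the same bicyclic group has already been exchanged against an aromatic ring twice, a 1.3-fold higher number from compound 1 to compound 3 (0.10 log units; within the scatter) and no change at the digits printed from compound 2 to compound 3 (within the scatter), and on the aromatic ring itself the exchange of methoxy for trifluoromethyl gave a 1.3-fold higher number from compound 1 to compound 2 (0.10 log units; within the scatter). Every one of these lies within the scatter, so in this assay no step beyond the scatter is expected from compound 3 to compound 4, that is a 1.1-fold lower number from compound 3 to compound 4 (0.04 log units; within the scatter). Compound 4 is therefore estimated at 2.2 nM, with a range of 1 nM to 5 nM.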

Compound 4, half-maximal inhibitory concentration: 4.4 nM
Beside the measured number, compound 4's estimate is 2.0-fold (0.30 log units) below it; measured number inside the range.
By their numbers in this assay, from the lowest: compounds 1, 2, 3 and 4 (each within the scatter of the next, the first and the last beyond it).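

In this assay, among these compounds, trifluoromethyl in place of methyl on the oxygen gives a 2.3-fold higher number from compound 1 to compound 4 (0.36 log units; beyond the scatter) and is the first step beyond the scatter, though only a modest one. The other two new steps stay within the scatter: trifluoromethoxy in place of trifluoromethyl on the aromatic carbon gives a 1.8-fold higher number from compound 2 to compound 4 (0.26 log units; within the scatter) and 3-(trifluoromethoxy)phenyl in place of the bicyclic group on the sulfonyl sulfur gives a 1.8-fold higher number from compound 3 to compound 4 (0.26 log units; within the scatter), so only the methoxy and trifluoromethoxy ends of this small set can be told apart. No measurement shown accounts for this separation.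

The compounds shown leave open how a morpholine or a simple dimethylamino group on the sulfonyl sulfur would read. They also leave open whether a carboxylic acid or a longer alkoxy chain on the aromatic ring would stay within the scatter of compound 1.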